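The source may report more compounds than this note shows. Statements on the series, on what has been measured and on what is new or still open speak of the compounds shown alone.

Measured compounds in an assay on CHO cells for displacement of a labelled ligand from Neuronal acetylcholine receptor; alpha3/alpha6/beta2/beta3 (Homo sapiens), read by scintillation counting; on this read-out lower numbers stand for stronger inhibition and higher numbers for weaker inhibition:
compound 1, `CC(=O)N1CC2CC(C1)N2`: 610 nM
compound 2, `CCC(=O)N1CC2CC(C1)N2`: 190 nM
compound 3, `CC(C)C(=O)N1CC2CC(C1)N2`: 580 nM

Compound 3 stands second highest of the three numbers; its value and that of compound 1 lie within the scatter of each other, while the step of a 3.1-fold higher number from compound 2 to compound 3 (0.48 log units; beyond the scatter) lies beyond it. Compound 4, `O=C([C@H]1C[C@H]1F)N1CC2CC(C1)N2`, differs from compound 3 by 2-fluorocyclopropyl in place of isopropyl on a carbonyl carbon. For the measured compounds named here, two measured steps concern the same carbonyl carbon: a 1.1-fold lower number from compound 1 to compound 3 (0.02 log units; within the scatter) and a 3.1-fold higher number from compound 2 to compound 3 (0.48 log units; beyond the scatter). Going by the values given here, the three-membered ring and the fluorine of compound 4 have no counterpart among the measured compounds, so these steps give only a rough guide. Compound 4 is therefore expected to come out somewhat lower, by about a 1.7-fold lower number from compound 3 to compound 4 (0.22 log units; within the scatter). The estimate for compound 4 is 350 nM, with a range from 120 nM to 1000 nM.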

Compound 4, inhibition constant: 27 nM
Estimate against measurement, compound 4: 13-fold (1.11 log units) above; the measured number lies below the stated range.
By their numbers in this assay, from the lowest: compound 4; then compound 2; then compounds 3 and 1 (each within the scatter of the next).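

In this assay the carbonyl carbon proves able to carry a far larger gain than the simple alkyl groups showed: 2-fluorocyclopropyl brings a 21-fold lower number from compound 3 to compound 4 (1.33 log units; beyond the scatter) and a 23-fold lower number from compound 1 to compound 4 (1.35 log units; beyond the scatter) as well as a 7.0-fold lower number from compound 2 to compound 4 (0.85 log units; beyond the scatter) and so sets compound 4 apart from the rest. Among methyl, ethyl and isopropyl the steps had stayed modest or within the scatter, so this position responds more strongly than those groups indicated. Nothing available explains this result. Still open, from the compounds shown here alone, is whether a plain cyclopropyl without the fluorine, or 2-fluorocyclopropyl with the opposite stereochemistry, would give a step of this size.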